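Fluorinating the Terminal Phenyl of a Leukotriene Antagonist

The compounds below may be only part of what the source reports. "The series", "measured", "known", "first", "only" and "open" are said of these compounds alone.

The account concerns two measured compounds and one that awaits measurement. Compound 1 `Cc1c(CCCC(=O)O)c2cccc(/C=C/c3ccc(OCCCCc4ccccc4)cc3)c2n1CC(=O)O` was tested in a functional assay on CHO-K1 cells for antagonist activity at cysteinyl leukotriene receptor 1 (Homo sapiens), read by fluorescence and calcium flux, with stated times of 30 min and 1 h (a lower number here means a stronger inhibitor, a higher number a weaker inhibitor), where compound 1 gives 4.1 nM. Going by the values given here, compound 2 `Cc1c(Cl)cccc1CCCCOc1ccc(C#Cc2cccc3c(CCCC(=O)O)c(C)n(CC(=O)O)c23)cc1` is the only other compound with a number, and in this assay compound 2 gives 0.22 nM. Of the two numbers, compound 1 holds the higher one, and the gap to compound 2 lies beyond the usual scatter, so compound 1 is the weaker inhibitor of the pair. The structures of compound 1 and compound 2 differ in several places at once, so nothing is said here about any single change between them.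

The step followed is from compound 1 to compound 3 `Cc1c(CCCC(=O)O)c2cccc(/C=C/c3ccc(OCCCCc4c(F)ccc(F)c4F)cc3)c2n1CC(=O)O`, whose difference is 2,3,6-trifluorophenyl in place of phenyl on a saturated chain carbon, four bonds along the chain from an oxygen on an aromatic ring. The saturated chain and the oxygen on the aromatic ring are kept; only the outermost ring changes. Among the compounds with values here, no measured pair in this set isolates such a change, so the direction is uncertain. The expectation is a small step, a 1.4-fold lower number from compound 1 to compound 3 (0.14 log units; within the scatter), not clearly beyond the scatter. Compound 3 is estimated at 3 nM, within a range from 1 nM to 10 nM.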

Compound 3, half-maximal inhibitory concentration in the cysteinyl leukotriene receptor 1 assay: 2.4 nM
The estimate for compound 3 lay 1.3-fold (0.10 log units) above the measured number, and the stated range covers the measured number.
By their numbers in the cysteinyl leukotriene receptor 1 assay, from the lowest: compound 2; then compounds 3 and 1 (each within the scatter of the next).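

At this saturated chain carbon, four bonds along the chain from an oxygen on an aromatic ring, the outermost ring accepts 2,3,6-trifluorophenyl in place of phenyl with no clear shift in receptor potency: the cysteinyl leukotriene receptor 1 assay shows a 1.7-fold lower number from compound 1 to compound 3 (0.23 log units; within the scatter). The pair does separate, for in a physicochemical assay for permeability, using PAMPA, with a stated time of 4 h, at pH 6.2, tested at 50 uM (on this read-out higher numbers stand for higher permeability and lower numbers for lower permeability), compound 1 gives 1.3 10^-6 cm/s and compound 3 gives 4.4 10^-6 cm/s. The single change that leaves potency within the scatter therefore raises apparent permeability, so the two read-outs respond differently to this one replacement, and compound 3 keeps its potency while gaining on the second measure: the measured apparent permeability of compound 1, 1.3 10^-6 cm/s, and of compound 3, 4.4 10^-6 cm/s, a 3.4-fold higher number (0.53 log units; beyond the scatter)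

The compounds shown leave open whether all the fluorine atoms are needed for this gain, or whether a single fluorine on the outermost ring would give the same reading in each read-out. They also leave open how a chlorine, a methyl or a trifluoromethyl on that ring would behave, and whether a pyridine in place of the ring, or a longer chain leading to it, would keep the same balance of potency and permeability.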